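The source may report more compounds than this note shows. Statements on the series, on what has been measured and on what is new or still open speak of the compounds shown alone.

Three compounds share one core and differ only in the group attached to an aromatic carbon of a six-membered aromatic ring with 1 nitrogen. Compound 3 `CC(C(=O)NCc1ccc(C(F)(F)F)nc1-c1ccoc1)c1ccc(NS(C)(=O)=O)c(F)c1` carries a furan-3-yl there, and in an assay on CHO cells for antagonist activity at transient receptor potential cation channel subfamily V member 1 (Homo sapiens), read by FLIPR (on this read-out higher numbers stand for weaker inhibition and lower numbers for stronger inhibition), compound 3 gives 1.4 nM, the lowest of the three numbers. Compound 1 `CC(C(=O)NCc1ccc(C(F)(F)F)nc1-c1ccccc1F)c1ccc(NS(C)(=O)=O)c(F)c1` gives 63.3 nM in this assay, and compound 2 `COc1ccc(-c2nc(C(F)(F)F)ccc2CNC(=O)C(C)c2ccc(NS(C)(=O)=O)c(F)c2)cc1F` gives 4.2 nM. The steps of a 45-fold lower number from compound 1 to compound 3 (1.66 log units; beyond the scatter) and a 3.0-fold lower number from compound 2 to compound 3 (0.48 log units; beyond the scatter) show that changing the group at this position moves the number far beyond the scatter, and the step of a 15-fold lower number from compound 1 to compound 2 (1.18 log units; beyond the scatter) points the same way.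

Compound 4 `Cc1ccc(CCc2nc(C(F)(F)F)ccc2CNC(=O)C(C)c2ccc(NS(C)(=O)=O)c(F)c2)cc1` has not yet been measured. Its change from compound 3 is 2-(4-methylphenyl)ethyl in place of furan-3-yl on an aromatic carbon. For the measured compounds named here, none of the measured steps exchanges an aromatic ring for a chain of this kind, so the measured steps bear on it only loosely: they show that this position is sensitive and that compound 3 already holds the best number, so a move is more likely upward than downward. The expected step is a 7.1-fold higher number from compound 3 to compound 4 (0.85 log units; beyond the scatter). Compound 4 is therefore estimated at 10 nM, with a range from 1.5 nM to 80 nM.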

Compound 4, inhibition constant: 0.6 nM
The estimate for compound 4 lay 17-fold (1.22 log units) above the measured number; the measured number lies below the stated range.
By their numbers in this assay, from the lowest: compound 4; then compound 3; then compound 2; then compound 1.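

Compound 4 shows that this position does not need an aromatic ring attached directly to the core: in this assay, 2-(4-methylphenyl)ethyl, whose ring is carried on a chain, gives a 2.3-fold lower number from compound 3 to compound 4 (0.37 log units; beyond the scatter) and so goes beyond the best of the directly attached rings. It also gives a 7.0-fold lower number from compound 2 to compound 4 (0.85 log units; beyond the scatter) and a 110-fold lower number from compound 1 to compound 4 (2.02 log units; beyond the scatter), so the position accepts a group with more heavy atoms than any of the furan-3-yl, and the hydrogen-bond acceptor of furan-3-yl is not needed for a low number. Nothing available explains why this group gives the lowest number of the four.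

The compounds shown leave open whether the chain or the ring's methyl group matters, since neither is changed on its own. A benzyl group, a 2-phenylethyl group, a 3-phenylpropyl chain or an amine at this position would each separate these questions.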